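Naphthyl for Methoxyphenyl on a Pyrazolyl Oxindole Core

The compounds below may be only part of what the source reports. "The series", "measured", "known", "first", "only" and "open" are said of these compounds alone.

Measured compounds:
compound 1 `COc1ccc(-c2cc(-c3ccc(Cl)cc3)n(C3C(=O)Nc4ccc(Br)cc43)n2)cc1` 8100 nM
compound 2 `COc1ccc(-c2cc(-c3ccc(Cl)cc3)n(C3C(=O)Nc4ccc(Cl)cc43)n2)cc1` 6290 nM

Of the compounds shown here, two have been measured in a functional assay on cells (Cancer cell lines, Homo sapiens) for cytotoxicity, read by sulforhodamine B assay, with a stated time of 48 h; a lower number here means a stronger inhibitor of growth, a higher number a weaker inhibitor of growth. Compound 1 gives 8100 nM and compound 2 gives 6290 nM; the two differ only by the halogen on the oxindole ring, and the step of a 1.3-fold lower number from compound 1 to compound 2 (0.11 log units; within the scatter) is within the scatter, so compound 1 stands highest of the two numbers only nominally.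

Compound 3 `O=C1Nc2ccc(Br)cc2C1n1nc(-c2ccc3ccccc3c2)cc1-c1ccc(Cl)cc1` is not yet measured. Relative to compound 1 it carries naphthalen-2-yl in place of 4-methoxyphenyl on an aromatic carbon. Within the data shown here, none of the measured steps bears on this change: the only measured step concerns the halogen on the oxindole ring, not the aryl group on the five-membered ring. Without any comparable step, the expectation for compound 3 in this assay rests on compound 1 alone, and a step of a 1.2-fold lower number from compound 1 to compound 3 (0.10 log units; within the scatter) beyond the scatter is not expected. Compound 3 is therefore estimated at 6500 nM, within a wide range from 1800 nM to 23000 nM.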

Compound 3, concentration for 50% growth inhibition: 4300 nM
Compound 3: the middle estimate sits 1.5-fold (0.18 log units) above what was measured; low and high end bracket the measured number.
By their numbers in this assay, from the lowest: compounds 3, 2 and 1 (each within the scatter of the next).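

In this assay, putting naphthalen-2-yl in place of 4-methoxyphenyl on the aromatic carbon of the five-membered aromatic ring with 2 nitrogen gives a 1.9-fold lower number from compound 1 to compound 3 (0.28 log units; within the scatter). Among these compounds, this is the first reading at this position, as the earlier pair varied only the halogen. It shows that an aryl group without oxygen and with 2 six-membered aromatic rings can stand here with no change beyond the scatter, and no measurement on hand explains the small difference.

The compounds shown leave open whether naphthalen-2-yl would read the same on the core of compound 2, which carries chloro in place of bromo. They also leave open whether a group of another kind at this position, such as a carboxylic acid or a morpholine, would move the number beyond the scatter.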